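A few compounds are considered here, and "the series" means these few. Any claim that something is new, unique, unknown or untested is made for them only; others in the source may bear on it.

In a functional assay on A549 cells (Homo sapiens) for cytotoxicity, read by LDH release, with a stated time of 48 h (on this read-out lower numbers stand for stronger inhibition and higher numbers for weaker inhibition), compound 1 (`O=C(COc1c(F)cc(C(=O)c2ccc(F)cc2)cc1Cl)NNC(=O)c1ccc(=O)oc1`) gives 60200 nM. Compound 2 (`Cn1cnc(C(=O)NNC(=O)COc2c(F)cc(C(=O)c3ccc(F)cc3)cc2Cl)c1`) gives 40700 nM, and compound 3 (`O=C(COc1ccc(C(=O)c2ccccc2)cc1)NNC(=O)c1ccc(=O)oc1`) gives 90900 nM. Compound 1 therefore stands amid these three numbers, within the scatter of each of the other two. Compound 4 (`O=C(COc1c(F)cc(C(=O)c2ccc(Cl)cc2)cc1Cl)NNC(=O)c1ccc(=O)oc1`) keeps the core of compound 1 and alters a single substituent: chloro in place of fluoro on an aromatic carbon, which turns 4-fluorophenyl into 4-chlorophenyl. Among the compounds with values here, no measured step involves this exchange. Within the data shown here, the only step available, a 1.5-fold lower number from compound 1 to compound 2 (0.17 log units; within the scatter), replaces a different group, on a carbonyl carbon, and it stayed within the scatter. On that slender evidence, no change beyond the scatter is expected in this assay, and the direction cannot be firmly assigned. The expected step, a 1.2-fold lower number from compound 1 to compound 4 (0.08 log units; within the scatter), is correspondingly small. Compound 4 is estimated at 50000 nM, with an expected range from 22000 nM to 100000 nM.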

Compound 4, half-maximal inhibitory concentration: 84900 nM
Compound 4: the middle estimate sits 1.7-fold (0.23 log units) below what was measured, within the range that was stated.
By their numbers in this assay, from the lowest: compounds 2, 1, 4 and 3 (each within the scatter of the next, the first and the last beyond it).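

Turning 4-fluorophenyl into 4-chlorophenyl, on an aromatic carbon para to a large group, gives a 1.4-fold higher number from compound 1 to compound 4 (0.15 log units; within the scatter) in this assay, and this is a direct reading of the exchange. The earlier compounds shown here gave no reading at this position, and this one shows that, on the core of compound 1, chloro and fluoro there cannot be told apart in this read-out. No evidence at hand bears on this result.

On these data alone, with only these two halogens read at this position, it remains open whether an amine, a methoxy group or a carboxylic acid there would move the number beyond the scatter. As far as these compounds go, it also remains open whether the same exchange would read alike on compound 2, which carries a different group on the carbonyl carbon.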